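Taking One Methoxy Group Off Compound 1

The source may report more compounds than this note shows. Statements on the series, on what has been measured and on what is new or still open speak of the compounds shown alone.

compound 1 `COc1cccc(/C=C/C(=O)/C=C/c2ccc(OCc3cn(CCCCCOc4cc(=O)oc5ccccc45)nn3)c(OC)c2)c1`: 34%
compound 2 `COc1ccccc1/C=C/C(=O)/C=C/c1ccc(OCc2cn(CCCOc3cc(=O)oc4ccccc34)nn2)c(OC)c1`: 57%

Both values come from a functional assay on COLO 205 cells (Homo sapiens) for inhibition, read by sulforhodamine B assay, with a stated time of 48 h, tested at 50 uM; on this read-out lower numbers stand for less inhibition of growth and higher numbers for more inhibition of growth at the one concentration tested. Compound 1, at 34%, stands lower of the two, and the gap to compound 2, at 57%, lies beyond the usual scatter. These two compounds differ in more than one place, so their gap cannot be assigned to any single group.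

The next compound is compound 3 `COc1cc(/C=C/C(=O)/C=C/c2ccccc2)ccc1OCc1cn(CCCCCOc2cc(=O)oc3ccccc23)nn1`. Its change from compound 1 is hydrogen in place of methoxy on an aromatic carbon, which is hydrogen in place of methoxy on an aromatic carbon, turning 3-methoxyphenyl into phenyl. Going by the values given here, no measured pair shows this change alone, so the expectation is weakly founded: no clear direction and no shift beyond the scatter. The estimated step of a number 3 percentage points higher from compound 1 to compound 3 (within the scatter) is therefore expected to be small. For compound 3 the expected value is 37%. The expected range runs from 20% to 55%.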

Compound 3, percent growth inhibition at one concentration: 22%
For compound 3 the middle estimate is 15 percentage points above the measured one; the measured number falls inside the stated range.
By their numbers in this assay, from the lowest: compound 3; then compound 1; then compound 2.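

Going by these compounds alone, replacing the methoxy group with hydrogen, which turns 3-methoxyphenyl into phenyl, is the first single change that can be read on its own: in this assay it gives a number 12 percentage points lower from compound 1 to compound 3 (beyond the scatter). At this place on the core of compound 1, then, the methoxy group goes with more inhibition of growth than hydrogen, although this modest step rests on one pair alone. Nothing measured here gives a reason for the step.

The compounds shown leave open whether a hydroxyl group, a fluorine atom or an amine at this place would match or pass the methoxy group of compound 1. They also leave open whether the same step would appear with the different chain and methoxy placement of compound 2.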